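Swapping Trifluoromethyl for Cyano on the Sulfonyl Arene

This account rests on a few compounds, and the source may have more. Where it says the series, first, only, none or still open, it means among the compounds named here.

Of the compounds shown here, three have so far been measured in a functional assay on HCC1806 cells (Homo sapiens) for inhibition, read by sulforhodamine B assay, tested at 10 uM; on this read-out higher numbers stand for more inhibition at the one concentration tested (going by the name of the read-out) and lower numbers for less inhibition. Compound 1 `CN1CCN(c2ccc(C3=NN(S(=O)(=O)c4ccc(C#N)cc4)C(c4ccc(N(C)C)cc4)C3)cc2)CC1` gives 99.8%, compound 2 `CN(C)c1ccc(C2CC(c3ccc(-n4cncn4)cc3)=NN2C(=O)c2ccc(C(F)(F)F)cc2)cc1` gives 7%, and compound 3 `CN(C)c1ccc(C2CC(c3ccc(-n4cncn4)cc3)=NN2S(=O)(=O)c2ccc(C(F)(F)F)cc2)cc1` gives 37%, the second highest of the three numbers, well beyond the scatter from each of the other two. Compound 4 `CN(C)c1ccc(C2CC(c3ccc(-n4cncn4)cc3)=NN2S(=O)(=O)c2ccc(C#N)cc2)cc1` has not yet been measured; it differs from compound 3 in a single place: cyano in place of trifluoromethyl on an aromatic carbon. Compound 1 also carries a cyano group on its sulfonyl ring, yet it differs from compound 3 elsewhere too, so its high result cannot be credited to this one change alone. The step of a number 13 percentage points higher from compound 3 to compound 4 (beyond the scatter) is expected to be a modest rise in this assay, though it may well stay within the scatter. Compound 4 is therefore estimated at 50%, between 20% and 80%.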

Compound 4, a percentage reported as inhibition, at one concentration (the size of the read-out at that concentration, not a potency): 33.1%
For compound 4 the middle estimate is 16.9 percentage points above the measured one; low and high end bracket the measured number.
By their numbers in this assay, from the lowest: compound 2; then compounds 4 and 3 (each within the scatter of the next); then compound 1.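

In this assay the change from trifluoromethyl to cyano on the sulfonyl ring gives a number 3.9 percentage points lower from compound 3 to compound 4 (within the scatter) and so leaves the result unmoved at this position. Larger differences come from other places: (4-cyanophenyl)sulfonyl in place of (4-(trifluoromethyl)phenyl)carbonyl gives a number 26.1 percentage points higher from compound 2 to compound 4 (beyond the scatter) and 1H-1,2,4-triazol-1-yl in place of 4-methylpiperazin-1-yl gives a number 66.7 percentage points lower from compound 1 to compound 4 (beyond the scatter) in this series. No supporting data explain any of these steps.

Open still is whether an amine or a methoxy group on that ring would change the number, and how trifluoromethyl performs alongside 4-methylpiperazin-1-yl.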